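The source may hold more compounds than are shown below. What is called first, only, known or untested is meant among the compounds shown, and "the series" means these compounds.

The measured compounds are compound 1 `O=c1[nH]c2ccc(Cl)cc2n1Cc1c(F)cccc1F`, compound 2 `O=c1[nH]c2ccc(Cl)cc2n1Cc1cc(F)cc(F)c1` and compound 3 `Cc1ccc2[nH]c(=O)n(Cc3c(F)cccc3F)c2c1`, all tested in an ADME assay on MT4 cells (Homo sapiens) for cytotoxicity; on this read-out higher numbers stand for lower toxicity in this test and lower numbers for higher toxicity in this test.

In this assay compound 1 reaches only a limit of the assay, > 424000 nM. Compound 2 likewise reaches only a limit, > 424000 nM. Compound 3 gives a number, 236000 nM.

Compound 1 and compound 3 differ by methyl in place of chloro on an aromatic carbon, and that change gives an at least 1.7-fold lower number from compound 1 to compound 3 (0.25 log units; that floor lies within the scatter); the step has only a floor since compound 1 sits at the limit of > 424000 nM in this assay, at which 2 of the 3 values shown sit. Compound 1 and compound 2 are built from the same atoms joined differently; the difference between the two cores is not broken down here.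

Compound 4 `Cc1ccc2[nH]c(=O)n(Cc3cc(F)cc(F)c3)c2c1` has not been measured. It stands to compound 2 as compound 3 stands to compound 1, through (methyl in place of chloro on an aromatic carbon), the same change at the same place. For the measured compounds named here, compound 2 also sits at the limit that the limit of > 424000 nM in this assay, at which 2 of the 3 values shown sit, describes, so the step is expected to be an at least 1.6-fold lower number from compound 2 to compound 4 (0.22 log units; that floor lies within the scatter), matching the one from compound 1 to compound 3.

Compound 4 is therefore expected to give about 250000 nM, most likely between 110000 nM and 480000 nM. That would place compound 4 close to compound 3, which gives 236000 nM.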

Compound 4, half-maximal cytotoxic concentration: 73000 nM
Compound 4: the middle estimate sits 3.4-fold (0.53 log units) above what was measured; measured number below the stated range.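

In this assay, methyl in place of chloro on an aromatic carbon gives an at least 5.8-fold lower number from compound 2 to compound 4 (0.76 log units; beyond the scatter), so on the core of compound 2 the change lowers the number by more than the scatter. This shows that the change can be carried to a second core and that the direction seen from compound 1 to compound 3 recurs, although the floor for that earlier step does not by itself clear the scatter. It does not show whether the change has the same size on both cores, or that two pairs make a rule for the whole series, because each step starts from a limit and gives only a floor: the same change on two cores in this assay, an at least 1.7-fold lower number (0.25 log units; that floor lies within the scatter) from compound 1 to compound 3 and an at least 5.8-fold lower number (0.76 log units; beyond the scatter) from compound 2 to compound 4; the limit leaves it open whether they differ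

The compounds shown leave open how a methoxy group, a nitrile or an amine on that aromatic carbon would read in this assay. Where compound 1 and compound 2 truly lie also stays open, since each is recorded only as a limit of the assay: the limit of > 424000 nM in this assay, at which 2 of the 4 values shown sit.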